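A few compounds are considered here, and "the series" means these few. Any claim that something is new, unique, unknown or untested is made for them only; others in the source may bear on it.

Working notes on the series. Compound 1 `COC(=O)/C=C/C[C@H]1OCCC[C@@H]1O[Si](C)(C)C(C)(C)C` gives 48000 nM in a functional assay on MCF7S cells (Homo sapiens) for inhibition; on this read-out higher numbers stand for weaker inhibition of growth and lower numbers for stronger inhibition of growth. Compound 2 `CC(C)(C)[Si](C)(C)O[C@H]1CCCO[C@@H]1C/C=C/CO` gives 83000 nM in this assay; the change is hydroxymethyl in place of methoxycarbonyl on a double-bonded chain carbon bound to a double-bonded chain carbon, and the step is a 1.7-fold higher number from compound 1 to compound 2 (0.24 log units; within the scatter). Compound 3 `COC(=O)/C=C\[C@H]1OCCC[C@@H]1O[Si](C)(C)C(C)(C)C` gives 82000 nM in this assay; its core differs from that of compound 1 by 2-(methoxycarbonyl)ethenyl in place of 3-(methoxycarbonyl)prop-2-en-1-yl on a saturated ring carbon, a step of a 1.7-fold higher number from compound 1 to compound 3 (0.23 log units; within the scatter), while against compound 2 the step is a 1.0-fold lower number from compound 2 to compound 3 (0.01 log units; within the scatter). Compound 4 `CC(C)(C)[Si](C)(C)O[C@H]1CCCO[C@@H]1/C=C\CO` is not yet measured in this assay. For the measured compounds named here, it differs from compound 3 by hydroxymethyl in place of methoxycarbonyl on a double-bonded chain carbon bound to a double-bonded chain carbon, the same change, at the same place, as the one seen from compound 1 to compound 2. Resting on a 1.7-fold higher number from compound 1 to compound 2 (0.24 log units; within the scatter), the step from compound 3 to compound 4 is expected to be small, estimated at a 1.5-fold higher number from compound 3 to compound 4 (0.17 log units; within the scatter). Compound 4 is thus expected at about 120000 nM, with a range from 50000 nM to 300000 nM.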

Compound 4, concentration for total growth inhibition: 23000 nM
The estimate for compound 4 lay 5.2-fold (0.72 log units) above the measured number; measured number below the stated range.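

Hydroxymethyl in place of methoxycarbonyl does not carry over unchanged from one core to the other in this assay: the same change on two cores in this assay, a 1.7-fold higher number (0.24 log units; within the scatter) from compound 1 to compound 2 and a 3.6-fold lower number (0.55 log units; beyond the scatter) from compound 3 to compound 4, 6.2-fold (0.79 log units) apart, beyond the scatter of two such steps.
The new result is a 3.6-fold lower number from compound 3 to compound 4 (0.55 log units; beyond the scatter), and the other two new steps run the same way: a 3.6-fold lower number from compound 2 to compound 4 (0.56 log units; beyond the scatter) and a 2.1-fold lower number from compound 1 to compound 4 (0.32 log units; beyond the scatter).
With one pair per core, this shows that the outcome of the change depends on the core in these compounds, but not which feature of the core sets it or what the change would do on a further core.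

The compounds shown leave open whether an amine or a carboxylic acid in place of the hydroxymethyl would follow compound 4 or compound 3. They also leave open how a longer chain bearing the hydroxyl would behave.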